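This account rests on a few compounds, and the source may have more. Where it says the series, first, only, none or still open, it means among the compounds named here.

Compound 1 `CCCOC(=O)C1=C(C)NC(=S)NC1c1ccco1` gives 46% in an assay on membranes from HEK293 cells for displacement of a labelled ligand from adenosine receptor A2b (Homo sapiens), read by scintillation counting, with a stated time of 30 min, tested at 1 uM; on this read-out higher numbers stand for more inhibition at the one concentration tested (going by the name of the read-out) and lower numbers for less inhibition; compound 2 `CC1=C(C(=O)OCC(C)C)C(c2ccco2)NC(=S)N1` gives 18%.

Compound 2 stands lowest of the two numbers measured, separated from compound 1 by the step of a number 28 percentage points lower from compound 1 to compound 2 (beyond the scatter). Compound 3 `CC1=C(C(=O)OC(C)(C)C)C(c2ccco2)NC(=S)N1` differs from compound 2 by tert-butyl in place of isobutyl on an oxygen next to a carbonyl group. Within the data shown here, no measured step covers this change; the one step at hand concerns a different alteration of the group on that oxygen, so it indicates direction only loosely. For compound 3 a small downward step or none beyond the scatter is expected, a number 6 percentage points lower from compound 2 to compound 3 (within the scatter). The estimate for compound 3 is 12%, within 0% to 30%.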

Compound 3, a percentage reported as inhibition, at one concentration (the size of the read-out at that concentration, not a potency): 9%
The estimate for compound 3 lay 3 percentage points above the measured number; the measured number falls inside the stated range.
By their numbers in this assay, from the lowest: compounds 3 and 2 (each within the scatter of the next); then compound 1.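

With tert-butyl in place of isobutyl on an oxygen next to a carbonyl group, this assay shows a number 9 percentage points lower from compound 2 to compound 3 (within the scatter), so this assay does not separate these two branched groups. Against propyl at the same place, tert-butyl gives a number 37 percentage points lower from compound 1 to compound 3 (beyond the scatter), which leaves compound 1 beyond the scatter of both branched compounds. Nothing at hand gives a reason for this difference.

On these data alone, whether a shorter ethyl or a longer butyl chain on this oxygen would hold the number of compound 1 stays open. So does the effect of a carboxylic acid at this place.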